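The compounds below may be only part of what the source reports. "The series", "measured", "known", "first", "only" and "open" are said of these compounds alone.

Measured so far in a functional assay on MCF7 cells (Homo sapiens) for cytotoxicity, read by MTT assay, with a stated time of 72 h; a lower number here means a stronger inhibitor, a higher number a weaker inhibitor:
- compound 1, `CC(C)NC(=O)N1CCN(C(=S)SCc2cn(Cc3ccccc3F)nn2)CC1`: 1860 nM
- compound 2, `COc1cc(Cn2cc(CSC(=S)N3CCN(C(N)=O)CC3)nn2)cc(OC)c1OC`: > 128000 nM
- compound 3, `CCNC(=O)N1CCN(C(=S)SCc2cn(Cc3cc(OC)c(OC)c(OC)c3)nn2)CC1`: > 128000 nM

For compound 3 the value in this assay is a limit of the assay, not a number. For compound 2 the value is likewise a limit. Among the measured compounds shown here, the one single-point step measured, a step that the two limits leave unreadable from compound 2 to compound 3, is therefore unreadable in size, as noted in the limit of > 128000 nM in this assay, at which 2 of the 3 values shown sit.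

Compound 4, `COc1cc(Cn2cc(CSC(=S)N3CCN(C(=O)NC(C)C)CC3)nn2)cc(OC)c1OC`, differs from compound 3 by methyl in place of hydrogen on a saturated chain carbon bound to an amide-type nitrogen and a saturated chain carbon. For the measured compounds named here, the only step that bears on this change is the unreadable one from compound 2 to compound 3, so its size gives no guidance. Compound 1 carries the same isopropyl group but differs in a second place as well, so its value shows only that such a urea can be active. The step from compound 3 to compound 4 is expected to be a step that the limit leaves unreadable from compound 3 to compound 4, most likely no move beyond the scatter. For compound 4 the estimate is 150000 nM, within 25000 nM to 600000 nM, with a limit again the probable outcome.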

Compound 4, half-maximal inhibitory concentration: > 128000 nM
Compound 4: only a limit was reported (the forecaster's own chance of this, stated with the estimate: 70%); the middle value is on the limit's open side.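

No new step can be read, since compound 4, like compound 2 and compound 3, is reported only as a limit: the limit of > 128000 nM in this assay, at which 3 of the 4 values shown sit.

On these data alone, whether hydrogen, ethyl and isopropyl on the urea differ at all on this shared core remains open.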